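The source may hold more compounds than are shown below. What is called first, only, known or untested is meant among the compounds shown, and "the series" means these compounds.

Measured compounds:
- compound 1, `CN(C)C(=O)c1cccnc1NCCCN1CCN(c2ccccc2C#N)CC1`, 2 nM
- compound 2, `Cc1ccccc1N1CCN(CCCNc2ncccc2C(=O)N(C)C)CC1`, 2 nM
- compound 3, `CN(C)C(=O)c1cccnc1NCCCN1CCN(c2ccccc2C(F)(F)F)CC1`, 12.6 nM

In a functional assay for antagonist activity at Alpha-1A adrenergic receptor (Oryctolagus cuniculus) (a lower number here means tighter binding, a higher number weaker binding), compound 3 gives 12.6 nM, the highest number of the three measured, standing a 6.3-fold higher number from compound 1 to compound 3 (0.80 log units; beyond the scatter) and a 6.3-fold higher number from compound 2 to compound 3 (0.80 log units; beyond the scatter). Compounds 1 and 2 sit together: no change at the digits printed from compound 1 to compound 2 (within the scatter).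

Compound 4, `COc1ccc(N2CCN(CCCNc3ncccc3C(=O)N(C)C)CC2)c(OC)c1`, is not yet measured. It differs from compound 3 as follows: 2,4-dimethoxyphenyl in place of 2-(trifluoromethyl)phenyl on an amine nitrogen in a ring. The two measured steps that bear on this position, from compound 1 to compound 3 and from compound 2 to compound 3, both replaced a small group by trifluoromethyl and both gave a modest rise in the number. The reverse direction, trifluoromethyl leaving, has therefore twice been associated with a modest fall. No measured compound carries a methoxy group, so the second methoxy on the entering ring is not covered by any step shown.

On that basis, compound 4 is expected to give a lower number than compound 3, with the step estimated at a 3.6-fold lower number from compound 3 to compound 4 (0.56 log units; beyond the scatter). The estimate for compound 4 in this assay is 3.5 nM, expected range 1 nM to 12 nM.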

Compound 4, dissociation constant: 31.6 nM
Estimate against measurement, compound 4: 9.0-fold (0.96 log units) below; the measured number lies above the stated range.
By their numbers in this assay, from the lowest: compounds 1 and 2 (each within the scatter of the next); then compound 3; then compound 4.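

In this assay, a 2.5-fold higher number from compound 3 to compound 4 (0.40 log units; beyond the scatter) shows that losing trifluoromethyl from this position does not by itself lower the number when 2,4-dimethoxyphenyl is the entering group. The same entering group gives larger steps from the two lowest compounds, a 16-fold higher number from compound 2 to compound 4 (1.20 log units; beyond the scatter) and a 16-fold higher number from compound 1 to compound 4 (1.20 log units; beyond the scatter), so compound 4 has the highest number of the four, and this position on the ring amine nitrogen separates aryl groups that each have 10 heavy atoms. Nothing measured here accounts for this rise.

The two methoxy groups of compound 4 cannot be separated, and a phenyl ring carrying a single methoxy group would show whether one alone goes with the rise. An unsubstituted phenyl group or a chlorophenyl group would further test how this position responds to the aryl group it carries.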